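Swapping the Ester for a Phenoxy Group

The compounds below may be only part of what the source reports. "The series", "measured", "known", "first", "only" and "open" are said of these compounds alone.

In a functional assay on MIA PaCa-2 cells (Homo sapiens) for cytotoxicity, read by MTT assay, with a stated time of 72 h (a lower number here means a stronger inhibitor, a higher number a weaker inhibitor), compound 1 `NS(=O)(=O)c1ccc(NC2=CC(=O)c3ncncc3C2=O)cc1` gives > 10000 nM, which is a limit of the assay. Compound 2 `CCOC(=O)c1ccc(NC2=CC(=O)c3ncncc3C2=O)cc1` gives 5500 nM.

Among the compounds with values here, compound 2 thus holds the only actual number; compound 1 sits at the limit of > 10000 nM in this assay, at which 1 of the 2 values shown sits. Within the data shown here, the single measured step, an at least 1.8-fold lower number from compound 1 to compound 2 (0.25 log units; that floor lies within the scatter), is the only guide. Compound 3 `O=C1C(Nc2ccc(Oc3ccccc3)cc2)=CC(=O)c2ncncc21` carries the change (phenoxy in place of ethoxycarbonyl on an aromatic carbon). Among the measured compounds shown here, no measured step involves a phenoxy group, so the expectation is a small step in this assay, in no confident direction: compound 3 is estimated at 4500 nM (range 1500 nM to 14000 nM), which means an expected step of a 1.2-fold lower number from compound 2 to compound 3 (0.09 log units; within the scatter).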

Compound 3, half-maximal inhibitory concentration: 3700 nM
Beside the measured number, compound 3's estimate is 1.2-fold (0.09 log units) above it, and the stated range covers the measured number.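

Phenoxy and ethoxycarbonyl cannot be told apart at this position in this assay, even though phenoxy adds a six-membered aromatic ring: the change gives a 1.5-fold lower number from compound 2 to compound 3 (0.17 log units; within the scatter). Replacing sulfamoyl with phenoxy gives an at least 2.7-fold lower number from compound 1 to compound 3 (0.43 log units; beyond the scatter), and unlike the change from sulfamoyl to ethoxycarbonyl, this step clears the scatter. Compound 1 stands at a limit, so that step is only a floor: the limit of > 10000 nM in this assay, at which 1 of the 3 values shown sits.

The compounds shown leave open how an amine or a carboxylic acid would read at this position. On these data alone, whether a much stronger compound can be reached through this position also remains open.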